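Moving the hydroxyl group on a terpyridine-like core

The compounds below may be only part of what the source reports. "The series", "measured", "known", "first", "only" and "open" are said of these compounds alone.

In a functional assay on DU-145 cells (Homo sapiens) for cytotoxicity, read by CCK-8 assay (on this read-out lower numbers stand for stronger inhibition and higher numbers for weaker inhibition), the following compounds have been measured.
Compound 1 `Oc1ccccc1-c1cc(-c2cccs2)cc(-c2ccccc2O)n1` gives > 50000 nM, which is a limit of the assay and not a number (the limit of > 50000 nM in this assay, at which 1 of the 3 values shown sits).
Compound 2 `Oc1cccc(-c2cc(-c3cccs3)cc(-c3ccccc3O)n2)c1` gives 9300 nM.
Compound 3 `Oc1cccc(-c2cc(-c3ccccn3)cc(-c3ccccc3O)n2)c1` gives 17100 nM.

Compound 1 and compound 2 differ by one change, (3-hydroxyphenyl in place of 2-hydroxyphenyl on an aromatic carbon), and this change brought an at least 5.3-fold lower number from compound 1 to compound 2 (0.73 log units; beyond the scatter). Compound 2 and compound 3 differ in the group on the other side of the shared core, and there the step was a 1.8-fold higher number from compound 2 to compound 3 (0.26 log units; within the scatter). The difference between the cores of compound 1 and compound 3 is not broken down here.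

Compound 4 `Oc1cccc(-c2cc(-c3ccccn3)cc(-c3cccc(O)c3)n2)c1` is not yet measured in this assay. It differs from compound 3 by 3-hydroxyphenyl in place of 2-hydroxyphenyl on an aromatic carbon. Going by the values given here, this is the same kind of change as the one from compound 1 to compound 2, but its surroundings are not identical: in compound 3 the place is meta to a 3-hydroxyphenyl group and meta to a pyridin-2-yl group, whereas in compound 1 it was meta to a 2-hydroxyphenyl group and meta to a thiophen-2-yl group. For compound 4 the expected step is a 4.3-fold lower number from compound 3 to compound 4 (0.63 log units; beyond the scatter). Among the compounds with values here, that expectation rests on the step of an at least 5.3-fold lower number from compound 1 to compound 2 (0.73 log units; beyond the scatter), the only earlier example of this change, and on compound 3 giving 17100 nM as the starting point. The value of compound 1 is a limit of the assay (the limit of > 50000 nM in this assay, at which 1 of the 3 values shown sits), so the true size of that earlier step is not known, and the expectation is set somewhat smaller. Compound 4 is therefore estimated at 4000 nM, with a range from 1500 nM to 12000 nM.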

Compound 4, half-maximal inhibitory concentration: 3610 nM
Compound 4: middle estimate off by 1.1-fold (0.04 log units), on the high side; the range from low to high includes it.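

In this assay, putting 3-hydroxyphenyl in place of 2-hydroxyphenyl gave a 4.7-fold lower number from compound 3 to compound 4 (0.68 log units; beyond the scatter), so the change goes the same way in both pairs shown, although the group on the other side of the shared core is pyridin-2-yl in one and thiophen-2-yl in the other, and no more than these two cores can be spoken for. The direction therefore carried over from one core to the other, but whether the size of the step carried over as well cannot be said: the same change on two cores in this assay, an at least 5.3-fold lower number (0.73 log units; beyond the scatter) from compound 1 to compound 2 and a 4.7-fold lower number (0.68 log units; beyond the scatter) from compound 3 to compound 4; the limit leaves it open whether they differ Compound 1 gives > 50000 nM, which is a limit of the assay and not a number, so only the later step has a known size.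

Going by these compounds, what a methoxy group or an amine would do in place of the hydroxyl on the 3-hydroxyphenyl groups stays open, as does the effect of replacing the pyridin-2-yl group with a group that is not an aromatic ring, such as a carboxylic acid or a longer chain. On these data alone, it is also open whether the same change would give a step of similar size on a third core, or in any assay other than this assay.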